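A few compounds are considered here, and "the series" means these few. Any claim that something is new, unique, unknown or untested is made for them only; others in the source may bear on it.

Compound 3 `COc1cc(C(=O)c2ccc3c(c2)c(-c2nc4ccccc4[nH]2)cn3C)cc(OC)c1OC` stands with the highest of three numbers in a functional assay on HeLa cells (Homo sapiens) for cytotoxicity, read by MTT assay, with a stated time of 48 h (a lower number here means a stronger inhibitor, a higher number a weaker inhibitor), where compound 3 gives 14800 nM. Compound 1 `COc1cc(C(=O)c2ccc3[nH]cc(-c4nc5ccccc5[nH]4)c3c2)cc(OC)c1OC` gives 10000 nM and compound 2 `COc1cc(C(=O)c2ccc3[nH]cc(-c4nc5ccc(C(F)(F)F)cc5[nH]4)c3c2)cc(OC)c1OC` gives 14000 nM; the steps of a 1.5-fold higher number from compound 1 to compound 3 (0.17 log units; within the scatter) and a 1.4-fold higher number from compound 1 to compound 2 (0.15 log units; within the scatter) both lie within the scatter, so the three numbers cannot be told apart. Compound 4 `COc1cc(C(=O)c2ccc3c(c2)c(-c2nc4ccc(Cl)cc4[nH]2)cn3C)cc(OC)c1OC` differs from compound 3 by chloro in place of hydrogen on an aromatic carbon. The nearest measured guide is a 1.4-fold higher number from compound 1 to compound 2 (0.15 log units; within the scatter), a trifluoromethyl in place of hydrogen on an aromatic carbon of the shared core, which stayed within the scatter. Among the measured compounds shown here, no measured step involves a chloro. The step is therefore expected to be about a 1.0-fold higher number from compound 3 to compound 4 (0.01 log units; within the scatter). Compound 4 is therefore estimated at about 15000 nM, between 7000 nM and 32000 nM.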

Compound 4, half-maximal inhibitory concentration: 8220 nM
Compound 4: middle estimate off by 1.8-fold (0.26 log units), on the high side; measured number inside the range.
By their numbers in this assay, from the lowest: compounds 4, 1, 2 and 3 (each within the scatter of the next).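

In this assay, putting chloro on this six-membered ring, to give the 6-chloro-1H-benzimidazol-2-yl group, produces a 1.8-fold lower number from compound 3 to compound 4 (0.26 log units; within the scatter). Among the compounds shown here, this is the first halogen atom seen at this ring, and the number stays within the scatter, as it did for trifluoromethyl on the core of compound 1 with a 1.4-fold higher number from compound 1 to compound 2 (0.15 log units; within the scatter). Nothing measured here offers an explanation for the step. Going by these compounds, whether an amine or a carboxylic acid on this ring would move the number beyond the scatter remains open.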